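This account rests on a few compounds, and the source may have more. Where it says the series, first, only, none or still open, it means among the compounds named here.

Measured so far:
compound 1 `CC(C)C(Cc1ncc[nH]1)c1ccc(-c2ccc3cccc(F)c3c2)[nH]c1=O` gives 22100 nM in a physicochemical assay for solubility, in phosphate buffer, measured as kinetic solubility; a higher number here means a more soluble compound, a lower number a less soluble compound;
compound 2 `CC(C)C(c1noc(=O)[nH]1)c1ccc(-c2ccc3cccc(F)c3c2)[nH]c1=O` gives 32500 nM in this assay.

Compound 1 stands at the low end of these two numbers, but the gap to compound 2, a 1.5-fold higher number from compound 1 to compound 2 (0.17 log units; within the scatter), lies within the scatter, so the two compounds cannot be separated by this assay. Compound 3 `CC(C)C(CC(N)=O)c1ccc(-c2ccc3cccc(F)c3c2)[nH]c1=O` has not been measured. It differs from compound 1 in one place: carbamoyl in place of 1H-imidazol-2-yl on a saturated chain carbon, two bonds along the chain from an aromatic carbon. Among the measured compounds shown here, the only measured step, from compound 1 to compound 2, swaps one five-membered aromatic ring for another and stayed within the scatter; it bears on compound 3 only loosely, since the change to compound 3 removes the ring altogether and puts a short open group in its place. For the measured compounds named here, no measured step shows what that does. With nothing pointing in either direction, the expected step of a 1.1-fold higher number from compound 1 to compound 3 (0.05 log units; within the scatter) stays within the scatter. In this assay compound 3 is estimated at 25000 nM, with a range from 10000 nM to 60000 nM.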

Compound 3, solubility: 5600 nM
For compound 3 the middle estimate is 4.5-fold (0.65 log units) above the measured one; the whole stated range lies above it.
By their numbers in this assay, from the lowest: compound 3; then compounds 1 and 2 (each within the scatter of the next).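

In this assay this position proves sensitive to what it carries: carbamoyl in place of 1H-imidazol-2-yl gives a 3.9-fold lower number from compound 1 to compound 3 (0.60 log units; beyond the scatter) and so clears the scatter, which the swap of one five-membered aromatic ring for another did not do. The other ring-bearing compound points the same way, with a 5.8-fold lower number from compound 2 to compound 3 (0.76 log units; beyond the scatter) for the open group, so both compounds with a ring at this place stand on the same side of compound 3. Nothing available here gives a reason for this drop.

Three compounds cannot tell whether the step follows from losing the ring or from carbamoyl itself. On these data alone, how an amine, a carboxylic acid or a longer chain ending in carbamoyl would fall at this place remains open.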